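This account rests on a few compounds, and the source may have more. Where it says the series, first, only, none or still open, it means among the compounds named here.

Going by the values given here, in a functional assay on the whole organism (strain Wister albino) for inhibition, with Rattus norvegicus as the target, read by paw edema, with stated times of 1 h and 4 h, at a dose of 50 mg/kg by the intraperitoneal route (a lower number here means less inhibition, a higher number more inhibition at the dose given (going by the name of the read-out)), compound 2, with the structure `CN1C/C(=C\c2ccc(-c3cccs3)cc2)C(=O)[C@]2(C1)[C@@H](c1ccc(-c3cccs3)cc1)CN(C)[C@@]21C(=O)Nc2ccccc21`, gives 71.4%, the higher of the two numbers measured so far. Compound 1, with the structure `CN1C/C(=C\c2ccc(F)cc2)C(=O)[C@]2(C1)[C@@H](c1ccc(F)cc1)CN(C)[C@@]21C(=O)N(C)c2ccccc21`, gives 47.2% in this assay, a gap from compound 2 that lies beyond the usual scatter; since compound 1 differs from compound 2 in more than one place, the two values show only that gap and not which change carries it.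

Compound 3, with the structure `CN1C/C(=C\c2ccc(-c3cccs3)cc2)C(=O)[C@]2(C1)[C@@H](c1ccc(-c3cccs3)cc1)CN(C)[C@@]21C(=O)N(C)c2ccccc21`, has not yet been measured. It differs from compound 2 in one place: methyl in place of hydrogen on an amide-type nitrogen in a ring.

Among the compounds with values here, no pair of measured compounds differs by this change alone, so there is no measured step to lean on. The expected step from compound 2 to compound 3 in this assay is a number 6.4 percentage points lower from compound 2 to compound 3 (within the scatter), small and not clearly beyond the scatter in either direction. Compound 3 is therefore estimated to give 65% in this assay, with a range from 45% to 85%.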

Compound 3, a percentage reported as inhibition, in the whole organism at one dose (the size of the read-out at that dose, not a potency): 69.8%
For compound 3 the middle estimate is 4.8 percentage points below the measured one, and the stated range covers the measured number.
By their numbers in this assay, from the lowest: compound 1; then compounds 3 and 2 (each within the scatter of the next).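

The amide-type nitrogen in the ring now has a measured step of its own: in this assay, methyl in place of hydrogen gives a number 1.6 percentage points lower from compound 2 to compound 3 (within the scatter). On the core of compound 2, then, the amide hydrogen and a methyl at this position cannot be told apart by this read-out at this one dose. Nothing measured here offers an explanation for this result.

A longer chain such as ethyl, or a larger group such as benzyl or acetyl, on this nitrogen might not read the same way. Whether the same holds on the core of compound 1 also remains open, as no compound shown differs from compound 1 at this nitrogen alone.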